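From Cyanomethyl to Allyl on a Shared Core

The source may hold more compounds than are shown below. What is called first, only, known or untested is meant among the compounds shown, and "the series" means these compounds.

Compound 1 `N#Cc1c(-c2ccc(Cl)cc2)cc(-c2ccc(Cl)cc2)n([C@@H]2O[C@H](COC(=O)c3ccccc3)[C@@H](OC(=O)c3ccccc3)[C@H]2OC(=O)c2ccccc2)c1=O` and compound 2 `N#Cc1c(-c2ccc(Cl)cc2)cc(-c2ccc(Cl)cc2)n(CC2CO2)c1=O` share their core with compound 3 `N#CCn1c(-c2ccc(Cl)cc2)cc(-c2ccc(Cl)cc2)c(C#N)c1=O` and all three have been tested in a functional assay on HepG2 cells (Homo sapiens) for cytotoxicity, read by sulforhodamine B assay, with a stated time of 48 h (a higher number here means a weaker inhibitor, a lower number a stronger inhibitor), so far. There, compound 1 gives 8 ug/mL and compound 2 gives 6.2 ug/mL as two values within the usual scatter of each other. Compound 3 stands apart from this pair, reported as "not active" (no number reported) with no number attached, so its position can be told only in those words.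

Compound 4 `C=CCn1c(-c2ccc(Cl)cc2)cc(-c2ccc(Cl)cc2)c(C#N)c1=O` has not yet been measured. It differs from compound 3 by a single change, vinyl in place of cyano on a saturated chain carbon bound to an aromatic nitrogen with vinyl in place of cyano on a saturated chain carbon bound to an aromatic nitrogen. Cut one bond further out, the same difference reads cyanomethyl to allyl.

No measured step sizes this change, so the expectation in this assay stays loose. Compound 2 gives a number (6.2 ug/mL) with another group at that place, and compound 4 is expected to move in the stronger direction, from no number to a measurable reading, although it may also remain without one. In this assay the estimated value for compound 4 is 9 ug/mL within an expected range of 4 ug/mL to 25 ug/mL for a numerical result.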

Compound 4, half-maximal inhibitory concentration: 20 ug/mL
Compound 4: the middle estimate sits 2.2-fold (0.35 log units) below what was measured; the measured number falls inside the stated range.
By their numbers in this assay, from the lowest: compounds 2 and 1 (each within the scatter of the next); then compound 4.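

The allyl group of compound 4 shows that a small open chain at this place can give a reading in this assay, whereas the cyanomethyl group of compound 3 left only the words "not active"; with no number for compound 3, the size of that step cannot be read. Among these compounds, until now, the only numbers at this place came with the groups of compound 1 and compound 2, and a number here does not depend on keeping either of those groups. Vinyl still does not match oxiran-2-yl on the saturated chain carbon, giving a 3.2-fold higher number from compound 2 to compound 4 (0.51 log units; beyond the scatter), a modest weakening that lies beyond the usual scatter. Nothing available explains why cyano and vinyl part so sharply, or why vinyl falls short of oxiran-2-yl.

The compounds shown leave open whether the double bond of the allyl group matters, since a plain propyl chain does not appear among them. They also leave open how the reading would respond to a longer chain, or to an amine or a carboxylic acid in place of vinyl on the same saturated chain carbon.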